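Removing trifluoromethyl from the aryl thiosemicarbazone of compound 3

This account rests on a few compounds, and the source may have more. Where it says the series, first, only, none or still open, it means among the compounds named here.

Measured so far:
compound 1 `NC(=S)N/N=C/c1ccc2ccccc2n1` — 32700 nM
compound 2 `N#Cc1ccc(NC(=S)N/N=C/c2ccc3ccccc3n2)cc1` — 23700 nM
compound 3 `FC(F)(F)c1ccccc1NC(=S)N/N=C/c1ccc2ccccc2n1` — 20700 nM

All three compounds share one core and were tested in a functional assay on SGC-7901 cells (Homo sapiens) for antiproliferative activity, read by sulforhodamine B assay, with a stated time of 72 h; a lower number here means a stronger inhibitor, a higher number a weaker inhibitor. Compound 3, with its trifluoromethyl-bearing aryl group, gives 20700 nM; this value lies within the scatter of the value of compound 2 and of the value of compound 1, so the three cannot be placed in an order.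

The next compound, compound 4 `S=C(N/N=C/c1ccc2ccccc2n1)Nc1ccccc1`, has not yet been measured. It differs from compound 3 in one place: hydrogen in place of trifluoromethyl on an aromatic carbon.

Among the compounds with values here, only one measured step is available, and it concerns a different kind of change: a 1.4-fold lower number from compound 1 to compound 2 (0.14 log units; within the scatter). Within the data shown here, no measured step alters a substituent on the aryl ring itself, so nothing directly bears on the change from compound 3 to compound 4. Since even the addition of a whole aryl group moved the number within the scatter, no step beyond the scatter is expected here.

The step from compound 3 to compound 4 is therefore estimated as a 1.2-fold higher number from compound 3 to compound 4 (0.06 log units; within the scatter). Compound 4 is expected to give about 24000 nM, with a range of 10000 nM to 55000 nM.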

Compound 4, half-maximal inhibitory concentration: 26500 nM
The estimate for compound 4 lay 1.1-fold (0.04 log units) below the measured number; the range from low to high includes it.
By their numbers in this assay, from the lowest: compounds 3, 2, 4 and 1 (each within the scatter of the next).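

In this assay, hydrogen in place of trifluoromethyl on an aromatic carbon, ortho to a large group, gives a 1.3-fold higher number from compound 3 to compound 4 (0.11 log units; within the scatter) and so lies within the scatter, which gives this position its first measured step. Hydrogen in place of cyano on an aromatic carbon gives a 1.1-fold higher number from compound 2 to compound 4 (0.05 log units; within the scatter) and phenyl in place of hydrogen on an amide-type nitrogen gives a 1.2-fold lower number from compound 1 to compound 4 (0.09 log units; within the scatter) with both steps also within the scatter, so the plain phenyl cannot be separated from either the substituted aryl compounds or the compound with no aryl group. No measurement is at hand that could account for these numbers.

As far as these compounds go, whether an amine, a carboxylic acid or a longer chain at this position would move the number beyond the scatter remains open. From the compounds shown here alone, it also remains open whether any change on this aryl ring can separate these compounds at all.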